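An Oxirane in Place of the Ethynyl Group

The source may hold more compounds than are shown below. What is called first, only, known or untested is meant among the compounds shown, and "the series" means these compounds.

In an ADME assay for pharmacokinetics, read by LC-MS, in phosphate buffer, with a stated time of 72 h, at pH 7.4, tested at 250 uM (on this read-out higher numbers stand for a longer-lived compound and lower numbers for a shorter-lived compound), three compounds sharing one core have been measured. Compound 1 `C=CC(=O)Oc1cc(C(F)(F)F)cc(C(F)(F)F)c1` gives < 0.017 h, which is a limit of the assay rather than a number. Compound 2 `C=CS(=O)(=O)c1cc(C(F)(F)F)cc(C(F)(F)F)c1` likewise gives < 0.017 h, again a limit. Compound 3 `C#Cc1cc(C(F)(F)F)cc(C(F)(F)F)c1` gives > 50 h, also a limit, at the other end of the scale. Compound 3 thus stands highest among the values seen so far: it sits at the limit of > 50 h in this assay, at which 1 of the 3 values shown sits, whereas the other two sit at the limit of < 0.017 h in this assay, at which 2 of the 3 values shown sit. Replacing the (vinylcarbonyl)oxy group with ethynyl gave an at least 2900-fold higher number from compound 1 to compound 3 (3.46 log units; beyond the scatter), and replacing vinylsulfonyl with ethynyl gave an at least 2900-fold higher number from compound 2 to compound 3 (3.46 log units; beyond the scatter). Compound 4 `FC(F)(F)c1cc(C2CO2)cc(C(F)(F)F)c1` differs from compound 3 by oxiran-2-yl in place of ethynyl on an aromatic carbon. Neither measured step covers this change: both put ethynyl in place of a (vinylcarbonyl)oxy or vinylsulfonyl group, and oxiran-2-yl is none of these. A step of an at least 2.0-fold lower number from compound 3 to compound 4 (0.31 log units; beyond the scatter) is therefore expected, with considerable uncertainty in either direction. Compound 4 is expected to give 24 h, between 4 h and 150 h.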

Compound 4, half-life: > 50 h
Compound 4: only a limit was reported (the forecaster's own chance of this, stated with the estimate: 35%); middle value at least 2.0-fold (0.31 log units) from the limit.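

In this assay compound 4 gives > 50 h, which is a limit and not a number: the limit of > 50 h in this assay, at which 2 of the 4 values shown sit.

Oxiran-2-yl on this aromatic carbon gave an at least 2900-fold higher number from compound 2 to compound 4 (3.46 log units; beyond the scatter) when it took the place of vinylsulfonyl, and an at least 2900-fold higher number from compound 1 to compound 4 (3.46 log units; beyond the scatter) when it took the place of (vinylcarbonyl)oxy. Ethynyl is thus no longer the only group at this place to reach the upper limit of the read-out, and a three-membered ring with a hetero atom reaches it too, though the step from compound 3 to compound 4 cannot be read, as both values are limits.

Which of compound 3 and compound 4 lasts longer in this assay stays open. The compounds shown also leave open how an amine or a carboxylic acid on this aromatic carbon would fare.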